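The source may report more compounds than this note shows. Statements on the series, on what has been measured and on what is new or still open speak of the compounds shown alone.

The measured compounds and their values:

Compound 1, `O=c1[nH]c2cc[nH]c2c(=O)n1CCN1CCN(c2ccccc2Cl)CC1`, in an assay for binding affinity to Adrenergic receptor alpha-1 (Rattus norvegicus) (a higher number here means a weaker inhibitor, a lower number a stronger inhibitor), gives 0.94 nM.
Compound 2, `COc1ccccc1N1CCN(CCCn2c(=O)[nH]c3cc[nH]c3c2=O)CC1`, in this assay gives 28 nM.
Compound 3, `O=c1[nH]c2cc(-c3ccccc3)[nH]c2c(=O)n1CCN1CCN(c2ccccc2Cl)CC1`, in this assay gives 1.08 nM.

Compound 1 and compound 3 share a core and differ in one place: phenyl in place of hydrogen on an aromatic carbon. The step that this change made is a 1.1-fold higher number from compound 1 to compound 3 (0.06 log units; within the scatter), so the two values stand together. Compound 2 differs from compound 1 in more than one place, and the difference between the two cores is not broken down here; in this assay compound 2 gives the highest number of the three, and both of its gaps to compound 1 and compound 3 lie beyond the scatter.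

Compound 4, `COc1ccccc1N1CCN(CCCn2c(=O)[nH]c3cc(-c4ccccc4)[nH]c3c2=O)CC1`, has not been measured in this assay. It differs from compound 2 by phenyl in place of hydrogen on an aromatic carbon, the same change as that from compound 1 to compound 3, at the same kind of place. Within the data shown here, the step from compound 2 to compound 4 is expected to be a 1.1-fold higher number from compound 2 to compound 4 (0.03 log units; within the scatter), resting on the single earlier step of a 1.1-fold higher number from compound 1 to compound 3 (0.06 log units; within the scatter), which stayed within the scatter. For compound 4 in this assay the estimate is 30 nM, with a range from 12 nM to 75 nM. The range is wider than that single step because compound 1 gives 0.94 nM on a core different from that of compound 2.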

Compound 4, inhibition constant: 1.23 nM
Compound 4: middle estimate off by 24-fold (1.39 log units), on the high side, outside the stated range (below it).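

In this assay, phenyl in place of hydrogen on an aromatic carbon gave a 23-fold lower number from compound 2 to compound 4 (1.36 log units; beyond the scatter), so on the core of compound 2 the change made a large difference. Set beside the same change on the core of compound 1, the result did not carry from one core to the other: the same change on two cores in this assay, a 1.1-fold higher number (0.06 log units; within the scatter) from compound 1 to compound 3 and a 23-fold lower number (1.36 log units; beyond the scatter) from compound 2 to compound 4, 26-fold (1.42 log units) apart, beyond the scatter of two such steps This shows that, in this series, a step measured on one core cannot be assumed to hold on another, but with only two pairs it gives no general rule for the change and does not identify which difference between the cores matters.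

The cores differ both in the chain and in the methoxy group of compound 2 versus the chlorine of compound 1, and no compound shown separates these two differences. On these data alone, it also remains open whether another group at this place, such as an amine or a carboxylic acid, would follow phenyl on either core.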